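Trimming a Methoxy Group from the Strongest Binder

The source may report more compounds than this note shows. Statements on the series, on what has been measured and on what is new or still open speak of the compounds shown alone.

Measured so far:
- compound 1 `COc1cccc(Nc2nc3cccc(-c4c(F)cccc4OC)c3o2)n1`: 620 nM
- compound 2 `COc1cc(Nc2nc3cccc(-c4c(F)cccc4OC)c3o2)cc(OC)c1OC`: 20 nM

Both compounds share a core and differ only in the ring attached through the amine. In an assay on isolated protein for inhibition of ribosomal protein S6 kinase alpha-2 (Homo sapiens), with a stated time of 150 min (a higher number here means a weaker inhibitor, a lower number a stronger inhibitor), compound 2 gives 20 nM, the lowest of the two numbers, and compound 1 gives 620 nM, a gap well beyond the scatter.

Compound 3 `COc1cc(Nc2nc3cccc(-c4c(F)cccc4OC)c3o2)cc(OC)c1` has not yet been measured. Relative to compound 2, the change is hydrogen in place of methoxy on an aromatic carbon, a carbon ortho to two methoxy groups and para to a large group.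

Among the compounds with values here, no single-change step between measured compounds exists to calibrate this. The expectation is a modest loss, a step of a 2.5-fold higher number from compound 2 to compound 3 (0.40 log units; beyond the scatter) in this assay. Compound 3 is expected to give 50 nM, within a range from 15 nM to 200 nM.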

Compound 3, half-maximal inhibitory concentration: 210 nM
For compound 3 the middle estimate is 4.2-fold (0.62 log units) below the measured one; measured number outside the range, above it.
By their numbers in this assay, from the lowest: compound 2; then compound 3; then compound 1.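

Taking away one methoxy group, on the carbon ortho to two methoxy groups and para to a large group, gives an 11-fold higher number from compound 2 to compound 3 (1.02 log units; beyond the scatter) in this assay, a large step. Within the data shown here, this is the first single change that can be read on its own, and it shows that this carbon matters: the two remaining methoxy groups do not keep the number of compound 2. No measurement shown accounts for the size of this step. Still open, as far as these compounds go, is whether a different group on this carbon, such as a hydroxyl, a fluorine or an amine, would bring the number back towards that of compound 2.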